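Swapping thiophen-2-yl for phenyl at an assay limit

This account rests on a few compounds, and the source may have more. Where it says the series, first, only, none or still open, it means among the compounds named here.

Compound 1 `COc1ncnc2c1c(-c1ccccc1)cn2[C@@H]1O[C@H](CO)[C@@H](O)[C@H]1O`: > 20000 nM
Compound 2 `CSc1ncnc2c1c(-c1cccs1)cn2[C@@H]1O[C@H](CO)[C@@H](O)[C@H]1O`: > 20000 nM
Compound 3 `CSc1ncnc2c1c(-c1ccccc1)cn2[C@@H]1O[C@H](CO)[C@@H](O)[C@H]1O`: not yet measured

These compounds share one core and are compared in a functional assay on HCT-116 cells (Homo sapiens), read by MTT assay, with a stated time of 72 h; on this read-out lower numbers stand for stronger inhibition and higher numbers for weaker inhibition. In this assay compound 2 gives > 20000 nM, which is a limit of the assay and not a number. Compound 1 gives > 20000 nM, and this too is a limit. Neither compound therefore has an exact potency, and the two cannot be ranked: the limit of > 20000 nM in this assay, at which 2 of the 2 values shown sit.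

Compound 3 keeps the rest of compound 2 but carries phenyl in place of thiophen-2-yl on an aromatic carbon. Among the compounds with values here, no measured pair shows what this exchange does on its own, so any forecast is tentative. Phenyl does appear in compound 1, which gives > 20000 nM, again a limit. On that basis, no step beyond the usual scatter is expected in either direction, and a reading at the same limit is the likeliest result. The expected change is a number no higher from compound 2 to compound 3 (the limit leaves the size open). The estimate for compound 3 is 20000 nM, with an expected range from 9000 nM to 40000 nM.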

Compound 3, half-maximal inhibitory concentration: > 20000 nM
Compound 3: a limit, no number; the forecaster's own chance of this, stated with the estimate: 80%; the middle value sits exactly at the limit.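

In this assay, compound 3 stays at a limit, as do compound 1 and compound 2, so neither step to compound 3 can be read: the limit of > 20000 nM in this assay, at which 3 of the 3 values shown sit.

The compounds shown leave open whether either exchange, phenyl for thiophen-2-yl or methylsulfanyl for methoxy, changes potency at all.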